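Adding a Bromine to the Phenoxy Arm of Compound 2

A few compounds are considered here, and "the series" means these few. Any claim that something is new, unique, unknown or untested is made for them only; others in the source may bear on it.

Compound 1 `O=c1cc(-n2cc(-c3ccccc3)nn2)c2cc(Br)ccc2o1` and compound 2 `O=c1cc(-n2cc(COc3ccccc3)nn2)c2cc(Br)ccc2o1` share one core and differ in a single group. In a functional assay on A549 cells (Homo sapiens) for antiproliferative activity, read by MTT assay, with a stated time of 48 h (on this read-out higher numbers stand for weaker inhibition and lower numbers for stronger inhibition), compound 1 gives 11200 nM, and compound 2 gives 12300 nM. Within the data shown here, the only measured step, a 1.1-fold higher number from compound 1 to compound 2 (0.04 log units; within the scatter), leaves the two within the usual scatter of each other, so neither stands apart. Compound 3 `O=c1cc(-n2cc(COc3ccccc3Br)nn2)c2cc(Br)ccc2o1` arises from compound 2 by bromo in place of hydrogen on an aromatic carbon. Among the measured compounds shown here, no measured step covers this kind of change, and the one known step was small. The step is therefore expected to be a 1.0-fold lower number from compound 2 to compound 3 (0.01 log units; within the scatter). Compound 3 is estimated at 12000 nM, with a likely range from 4000 nM to 36000 nM.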

Compound 3, half-maximal inhibitory concentration: 8430 nM
Beside the measured number, compound 3's estimate is 1.4-fold (0.15 log units) above it, and the stated range covers the measured number.
By their numbers in this assay, from the lowest: compounds 3, 1 and 2 (each within the scatter of the next).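

Putting a bromo on the phenoxy arm, so that 2-bromophenoxy replaces phenoxy, gives a 1.5-fold lower number from compound 2 to compound 3 (0.16 log units; within the scatter) in this assay. Among these compounds, this is the first view of a change on the ring of that arm rather than of the arm as a whole, and adding this single heavy atom keeps the read-out within the usual scatter. Nothing at hand explains the result.

From the compounds shown here alone, whether a smaller chloro, a methoxy or an amine at this place would also stay within the scatter remains open. So does the outcome of placing bromo elsewhere on this ring.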